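Nitro in place of cyano on the thiourea aryl ring

This account rests on a few compounds, and the source may have more. Where it says the series, first, only, none or still open, it means among the compounds named here.

Three thioureas on the shared core have been measured in a functional assay on B16-F10 cells (Mus musculus) for inhibition, read by MTT assay, with a stated time of 72 h; a lower number here means a stronger inhibitor, a higher number a weaker inhibitor. Compound 1 `CC1(C)CC(NC(=S)Nc2ccc(C#N)cc2)c2cc(F)ccc2O1` gives 5000 nM, compound 2 `CC1(C)CC(NC(=S)Nc2cccc(C#N)c2)c2cc(F)ccc2O1` gives 35000 nM, and compound 3 `CC1(C)CC(NC(=S)Nc2ccccc2Cl)c2cc(Br)ccc2O1` gives 17000 nM. Among the measured compounds shown here, compound 2 therefore stands highest of the three numbers, above compound 3 and furthest from compound 1, and the only measured step, a 7.0-fold higher number from compound 1 to compound 2 (0.85 log units; beyond the scatter), is what separates it from compound 1.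

Compound 4 `CC1(C)CC(NC(=S)Nc2cccc([N+](=O)[O-])c2)c2cc(F)ccc2O1` differs from compound 2 by nitro in place of cyano on an aromatic carbon. For the measured compounds named here, no measured pair exchanges one substituent for another on the aryl ring of the thiourea, and the step of a 7.0-fold higher number from compound 1 to compound 2 (0.85 log units; beyond the scatter) concerns where the cyano sits rather than which group is present, so it bears only loosely on the present change. With nothing in the series pointing either way, no step beyond the scatter is expected in this assay, no change at the digits printed from compound 2 to compound 4 (within the scatter). Compound 4 is expected to give about 35000 nM, with a range from 12000 nM to 100000 nM to allow for the wide scatter around such weak values.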

Compound 4, half-maximal inhibitory concentration: 6000 nM
Estimate against measurement, compound 4: 5.8-fold (0.77 log units) above, and the stated range ends above it.
By their numbers in this assay, from the lowest: compounds 1 and 4 (each within the scatter of the next); then compound 3; then compound 2.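

In this assay, the exchange of one substituent for another on the aryl ring of the thiourea, on an aromatic carbon meta to a large group, gives a 5.8-fold lower number from compound 2 to compound 4 (0.77 log units; beyond the scatter). The number at this position therefore depends on which group is present, whereas a 7.0-fold higher number from compound 1 to compound 2 (0.85 log units; beyond the scatter) showed only that it depends on where the cyano sits. Nothing available explains why nitro gives the lower number here.

From the compounds shown here alone, whether an amine, a carboxylic acid or a trifluoromethyl at this position would give a number nearer to that of compound 2 or of compound 4 remains open. Also open, going by these compounds, is how the number would respond if the nitro were moved elsewhere on the ring with the rest of compound 4 unchanged.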